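Swapping benzyloxy for chloro on a boron-containing chalcone

The source may report more compounds than this note shows. Statements on the series, on what has been measured and on what is new or still open speak of the compounds shown alone.

Compound 1 `COc1ccc(C(=O)/C=C/c2ccc3c(c2)B(O)OC3)cc1OC` reaches only the assay limit > 10 ug/mL in an ADME assay on L929 cells (Mus musculus) for cytotoxicity, read by resazurin assay, with a stated time of 72 h; on this read-out lower numbers stand for stronger inhibition and higher numbers for weaker inhibition.
Compound 2 `O=C(/C=C/c1ccc2c(c1)B(O)OC2)c1ccc(OCc2ccccc2)cc1` likewise reaches only the limit > 10 ug/mL in this assay.
Compound 3 `COc1cc(C(=O)/C=C/c2ccc3c(c2)B(O)OC3)ccc1[N+](=O)[O-]` also reaches only the limit > 10 ug/mL in this assay.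

Compound 2 thus sits at the limit, as do the other two values shown, which is all that the limit of > 10 ug/mL in this assay, at which 3 of the 3 values shown sit, records. Among the measured compounds shown here, the one measured step, a step that the two limits leave unreadable from compound 1 to compound 3, cannot be read because both ends are limits. Compound 4 `O=C(/C=C/c1ccc2c(c1)B(O)OC2)c1ccc(Cl)cc1` arises from compound 2 by the change (chloro in place of benzyloxy on an aromatic carbon). For the measured compounds named here, no measured step bears on this change, so no shift beyond the usual scatter in this assay can be expected. Compound 4 is therefore estimated at 15 ug/mL, within 6 ug/mL to 40 ug/mL. The expected step is a step that the limit leaves unreadable from compound 2 to compound 4.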

Compound 4, half-maximal inhibitory concentration: > 10 ug/mL
Compound 4: only a limit was reported; the forecaster's own chance of this, stated with the estimate: 70%; the middle value lies beyond the limit too.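

Compound 2 and compound 4 each give only a limit rather than a number, so no step can be read between them: the limit of > 10 ug/mL in this assay, at which 4 of the 4 values shown sit. The compounds shown leave open how far each lies beyond that limit, and whether chloro in place of benzyloxy changes the result at all.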